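Replacing the 2-bromobenzyl group of compound 2

A few compounds are considered here, and "the series" means these few. Any claim that something is new, unique, unknown or untested is made for them only; others in the source may bear on it.

Compound 1 `Cc1cc(N2CC[C@@H](C)[C@@H](N(C)c3ncnc4[nH]ccc34)C2)n2nc(SCc3ccccc3)nc2n1`: 67200 nM
Compound 2 `Cc1cc(N2CC[C@@H](C)[C@@H](N(C)c3ncnc4[nH]ccc34)C2)n2nc(SCc3ccccc3Br)nc2n1`: > 100000 nM (a limit of the assay)

Both compounds were tested in a toxicity assay on GES1 cells (Homo sapiens) for inhibition, read by MTT assay, with a stated time of 72 h; on this read-out lower numbers stand for stronger inhibition and higher numbers for weaker inhibition. Compound 2 has no number there, only a limit of > 100000 nM. Compound 3 `Cc1cc(N2CC[C@@H](C)[C@@H](N(C)c3ncnc4[nH]ccc34)C2)n2nc(SCc3csc4ccc(Cl)cc34)nc2n1` carries (5-chloro-1-benzothiophen-3-yl)methyl in place of the 2-bromobenzyl group of compound 2: 5-chloro-1-benzothiophen-3-yl in place of 2-bromophenyl on a saturated chain carbon bound to a sulfur.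

Among the compounds with values here, one measured step bears on this change: an at least 1.4-fold higher number from compound 1 to compound 2 (0.17 log units; that floor lies within the scatter). Within the data shown here, it rests on (the limit of > 100000 nM in this assay, at which 1 of the 2 values shown sits), and no measured step exchanges the whole aromatic group. Among the measured compounds shown here, the only true number remains that of compound 1, 67200 nM, so a value in that region is expected. Another limit would be no surprise. The step expected in this assay is an at least 1.5-fold lower number from compound 2 to compound 3 (0.18 log units; that floor lies within the scatter), with no clear direction beyond the scatter. For compound 3 the estimated value is 65000 nM, with an expected range from 20000 nM to 180000 nM.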

Compound 3, half-maximal inhibitory concentration: > 100000 nM
Compound 3: a limit, no number; the forecaster's own chance of this, stated with the estimate: 35%; at least 1.5-fold (0.18 log units) between middle value and limit.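

In this assay compound 3, like compound 2, gives only a limit and no number, so the step between these two cannot be read. Within the data shown here, the one readable step for the new group is an at least 1.4-fold higher number from compound 1 to compound 3 (0.17 log units; that floor lies within the scatter), so the exchange of phenyl for 5-chloro-1-benzothiophen-3-yl on a saturated chain carbon bound to a sulfur establishes no change beyond the scatter. What compound 3 adds is that a group of two aromatic rings at this place also ends at the limit, which leaves compound 1 as the only one of the three with a true number: the limit of > 100000 nM in this assay, at which 2 of the 3 values shown sit.

The compounds shown leave open how far the true values of compound 2 and compound 3 lie from the limit. They also leave open whether an amine or a carboxylic acid in place of the aromatic group would give a number in this assay.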